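Chloro to Methyl on the Aryl Ring: Compound 4 Expected

The source may report more compounds than this note shows. Statements on the series, on what has been measured and on what is new or still open speak of the compounds shown alone.

Three compounds have been measured in a functional assay on MOLT-4 cells (Homo sapiens) for inhibition, with a stated time of 3 days; on this read-out higher numbers stand for weaker inhibition and lower numbers for stronger inhibition:
- compound 1 `Cc1c(C(=O)/C=C/c2cccc([N+](=O)[O-])c2)[n+]([O-])c2ccccc2[n+]1[O-]` gives 16300 nM
- compound 2 `COc1ccc(/C=C/C(=O)c2c(C)[n+]([O-])c3ccccc3[n+]2[O-])cc1OC` gives 18500 nM
- compound 3 `Cc1c(C(=O)/C=C/c2ccc(Cl)cc2)[n+]([O-])c2ccccc2[n+]1[O-]` gives 7750 nM

Compound 3 has the lowest number of the three, which on this read-out means the strongest inhibition. Its nearest neighbour is compound 1, whose number is higher by more than the usual scatter, and compound 2 lies further away still, again beyond the scatter. So compound 3 is the most potent of the measured set.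

Compound 4 `Cc1ccc(/C=C/C(=O)c2c(C)[n+]([O-])c3ccccc3[n+]2[O-])cc1` differs from compound 3 in one place: methyl in place of chloro on an aromatic carbon. One small group is traded for another of the same size, with no change in hydrogen bonding or charge, and the ring it sits on is otherwise untouched.

For the measured compounds named here, no pair of measured compounds differs in a single place, so there is no measured step to lean on. Without such a guide, the exchange is expected to move the number only a little, if at all beyond the scatter, most likely toward slightly weaker inhibition; that expected shift is a 1.3-fold higher number from compound 3 to compound 4 (0.11 log units; within the scatter). Compound 4 is therefore estimated at 10000 nM, within a range of 4000 nM to 25000 nM.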

Compound 4, half-maximal inhibitory concentration: 8400 nM
For compound 4 the middle estimate is 1.2-fold (0.08 log units) above the measured one, and the stated range covers the measured number.
By their numbers in this assay, from the lowest: compounds 3, 4, 1 and 2 (each within the scatter of the next, the first and the last beyond it).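

In this assay, for the compounds shown here, this is the first change in a single place, and it gives a 1.1-fold higher number from compound 3 to compound 4 (0.03 log units; within the scatter). At this spot, para to a large group, the 4-chlorophenyl and 4-methylphenyl versions therefore cannot be told apart, which shows that the chlorine atom itself is not needed to keep this level of inhibition and that a methyl carbon can stand in its place on this read-out. No supporting measurement is available to explain this match between the two groups.

Chloro and methyl are both single heavy atoms with no hydrogen-bond donors or acceptors, so this one step says little about how much freedom this place really allows; an amine, a carboxylic acid or a longer chain such as hexyl could behave quite differently on the same ring. On these data alone, it also remains open whether chloro and methyl would still match if they sat on another carbon of the ring, or if another part of the shared core were changed at the same time.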